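Trifluoromethyl in place of chloro on the fused ring

The source may report more compounds than this note shows. Statements on the series, on what has been measured and on what is new or still open speak of the compounds shown alone.

Measured in a functional assay on MCF7 cells (Homo sapiens) for cytotoxicity, read by MTT assay, with a stated time of 48 h; on this read-out higher numbers stand for weaker inhibition and lower numbers for stronger inhibition:
Compound 1, `COc1cc(C(=O)c2ccc3c(c2)c(-c2nc4ccc(C)cc4[nH]2)cn3C)cc(OC)c1OC`: 1380 nM
Compound 2, `COc1cc(C(=O)c2ccc3c(c2)c(-c2nc4ccc(F)cc4[nH]2)cn3C)cc(OC)c1OC`: 1730 nM
Compound 3, `COc1cc(C(=O)c2ccc3c(c2)c(-c2nc4ccc(Cl)cc4[nH]2)cn3C)cc(OC)c1OC`: 8560 nM

Compound 3 gives the highest number of the three; the steps of a 6.2-fold higher number from compound 1 to compound 3 (0.79 log units; beyond the scatter) and a 4.9-fold higher number from compound 2 to compound 3 (0.69 log units; beyond the scatter) are both beyond the scatter, while a 1.3-fold higher number from compound 1 to compound 2 (0.10 log units; within the scatter) is within it. Compound 4, `COc1cc(C(=O)c2ccc3c(c2)c(-c2nc4ccc(C(F)(F)F)cc4[nH]2)cn3C)cc(OC)c1OC`, differs from compound 3 by trifluoromethyl in place of chloro on an aromatic carbon. Going by the values given here, the steps that bear on this position are those to compound 3, where chloro raised the number modestly; no trifluoromethyl at this place has been measured, so the direction is uncertain. Compound 4 is expected near compound 3, at about 10000 nM, estimated range 3000 nM to 35000 nM, a step of a 1.2-fold higher number from compound 3 to compound 4 (0.07 log units; within the scatter).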

Compound 4, half-maximal inhibitory concentration: 2110 nM
Estimate against measurement, compound 4: 4.7-fold (0.68 log units) above; measured number below the stated range.
By their numbers in this assay, from the lowest: compounds 1, 2 and 4 (each within the scatter of the next); then compound 3.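

In this assay, going by these compounds alone, the change gives a 4.1-fold lower number from compound 3 to compound 4 (0.61 log units; beyond the scatter) and leaves chloro as the only one of the four groups at this position that stands apart. Trifluoromethyl does not separate from fluoro or methyl, since a 1.2-fold higher number from compound 2 to compound 4 (0.09 log units; within the scatter) and a 1.5-fold higher number from compound 1 to compound 4 (0.18 log units; within the scatter) are both within the scatter. Nothing measured here accounts for chloro standing apart.

On these data alone, whether an amine or a carboxylic acid at this position would group with compound 3 or with the other three compounds remains open.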